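Adding One Fluorine Atom and Watching Cell Toxicity

The compounds below may be only part of what the source reports. "The series", "measured", "known", "first", "only" and "open" are said of these compounds alone.

Two compounds that share a common core were tested in an ADME assay on L02 cells (Homo sapiens) for cytotoxicity, read by MTT assay, with a stated time of 24 h; on this read-out higher numbers stand for lower toxicity in this test and lower numbers for higher toxicity in this test. Compound 1 `O=c1[nH]cc(S(=O)(=O)Nc2cccc(-c3cn(-c4ccccc4)nn3)c2)c(=O)[nH]1` sits at the edge of what this test can report, giving > 100000 nM, and this is a limit of the assay rather than a measured number. Compound 2 `O=c1[nH]cc(S(=O)(=O)Nc2ccc(-c3cn(-c4ccccc4)nn3)cc2)c(=O)[nH]1` was described only in words, giving "not toxic" (no number reported), so no number exists for it either. Where compound 2 stands therefore cannot be fixed on a scale; the only other value shown for comparison is the limit of > 100000 nM in this assay, at which 1 of the 2 values shown sits.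

Compound 3 `O=c1[nH]cc(S(=O)(=O)Nc2ccc(-c3cn(-c4ccccc4F)nn3)cc2)c(=O)[nH]1` has not yet been measured. It differs from compound 2 in one place: fluoro in place of hydrogen on an aromatic carbon. Going by the values given here, no pair of measured compounds differs in a single place, so no step size can be read from the data. Since neither measured compound reached a concentration that harmed the cells, the change from compound 2 to compound 3 is expected to produce no shift beyond the usual scatter in this assay. Compound 3 is accordingly expected to give about 100000 nM in this assay, with a range from 50000 nM to 200000 nM, and will most likely be reported only as a limit once more.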

Compound 3, half-maximal cytotoxic concentration: > 100000 nM
Compound 3: only a limit was reported; the forecaster's own chance of this, stated with the estimate: 85%; the middle value sits exactly at the limit.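

No step can be read between compound 2 and compound 3, as neither carries a number on this scale. In this assay compound 3 gives > 100000 nM, which is a limit and not a number. The compounds shown leave open whether phenyl to 2-fluorophenyl changes cell toxicity at all, and at what concentration any of them would harm these cells: the limit of > 100000 nM in this assay, at which 2 of the 3 values shown sit.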